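One Aryl Exchange, Two Cores: Expecting Compound 4

The source may hold more compounds than are shown below. What is called first, only, known or untested is meant among the compounds shown, and "the series" means these compounds.

Three compounds built on a shared core were examined in a functional assay on CCRF-CEM cells (Homo sapiens) for inhibition, read by MTT assay, with a stated time of 72 h; on this read-out lower numbers stand for stronger inhibition and higher numbers for weaker inhibition. Compound 3 `COc1cc(NC(C)CCCNC(=O)NNC(=O)Nc2cccc(C(F)(F)F)c2)c2ncccc2c1` gives 6900 nM, compound 1 `COc1cc(NC(C)CCCNC(=O)NNC(=O)Nc2ccc(Cl)cc2)c2ncccc2c1` gives 108000 nM, and compound 2 `COc1cc(NC(C)CCCNC(=O)Nc2cccc(C(F)(F)F)c2)c2ncccc2c1` gives 19000 nM. Compound 4 `COc1cc(NC(C)CCCNC(=O)Nc2ccc(Cl)cc2)c2ncccc2c1` has not yet been measured in this assay.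

The exchange 4-chlorophenyl in place of 3-(trifluoromethyl)phenyl on an amide-type nitrogen produced a 16-fold higher number from compound 3 to compound 1 (1.19 log units; beyond the scatter). A second exchange gave a 5.7-fold lower number from compound 1 to compound 2 (0.75 log units; beyond the scatter). How the core of compound 2 differs from the core of compound 3 is not broken down here. Compound 4 carries the same exchange relative to compound 2 that compound 1 carries relative to compound 3: 4-chlorophenyl in place of 3-(trifluoromethyl)phenyl on an amide-type nitrogen, and the place is described in the same words for both pairs.

Because the step of a 16-fold higher number from compound 3 to compound 1 (1.19 log units; beyond the scatter) was large, compound 4 is expected to show a rise of similar direction, estimated as a 7.9-fold higher number from compound 2 to compound 4 (0.90 log units; beyond the scatter). The surrounding core is not the same in the two pairs, so the expected figure is held somewhat below the earlier step. Compound 4 is therefore expected to give about 150000 nM, most likely between 40000 nM and 500000 nM.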

Compound 4, half-maximal inhibitory concentration: 24000 nM
For compound 4 the middle estimate is 6.3-fold (0.80 log units) above the measured one; the measured number lies below the stated range.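

On the core of compound 2, the exchange to 4-chlorophenyl gave a 1.3-fold higher number from compound 2 to compound 4 (0.10 log units; within the scatter), so in this assay the two aryl groups cannot be told apart on that core. The same exchange therefore did not carry over from one core to the other with its size intact: the same change on two cores in this assay, a 16-fold higher number (1.19 log units; beyond the scatter) from compound 3 to compound 1 and a 1.3-fold higher number (0.10 log units; within the scatter) from compound 2 to compound 4, 12-fold (1.09 log units) apart, beyond the scatter of two such steps With 4-chlorophenyl on both compounds, the difference in the core gave a 4.5-fold lower number from compound 1 to compound 4 (0.65 log units; beyond the scatter), yet these two pairs do not show which part of the core sets the gap, nor how the exchange would behave on any further core.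

The compounds shown leave open whether the same gap between the cores would appear with other groups on the amide-type nitrogen, such as a phenyl ring carrying a carboxylic acid or an amine. They also leave open whether a longer chain in the shared part of these structures would change the picture.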